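A few compounds are considered here, and "the series" means these few. Any claim that something is new, unique, unknown or untested is made for them only; others in the source may bear on it.

Measured in an ADME assay on PC-12 cells (Rattus norvegicus) for cytotoxicity, read by WST assay, with a stated time of 24 h; on this read-out lower numbers stand for higher toxicity in this test and higher numbers for lower toxicity in this test:
- compound 1 `O=C(/C=C/c1ccc(O)c(O)c1)CC(=O)/C=C/c1cc(O)ccc1O`: 51000 nM
- compound 2 `O=C(/C=C/c1cc(O)ccc1O)CC(=O)/C=C/c1cc(O)ccc1O`: 24000 nM
- compound 3 `O=C(/C=C/c1ccc(O)c(O)c1)/C=C/c1ccccc1O`: 34000 nM

Compound 3, at 34000 nM, lies within the usual scatter of both compound 1 and compound 2, so it cannot be ranked against either of them. The unmeasured compound 4 `O=C(/C=C/c1cccc(O)c1)/C=C/c1ccc(O)c(O)c1` has the same atoms as compound 3, joined differently: 3-hydroxyphenyl in place of 2-hydroxyphenyl on a double-bonded chain carbon bound to a double-bonded chain carbon.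

Among the measured compounds shown here, only one measured step bears on this change. It is a 2.1-fold lower number from compound 1 to compound 2 (0.33 log units; beyond the scatter), a modest step that also exchanges one hydroxyphenyl group for another with the same atoms, though on the core of compound 1 rather than that of compound 3. For the measured compounds named here, with only this small precedent, and on a different core, the data offer no firm direction, and no change beyond the scatter is expected. The estimated step is a 1.1-fold higher number from compound 3 to compound 4 (0.05 log units; within the scatter). For compound 4 the expected value is 38000 nM, with an estimated range from 19000 nM to 75000 nM.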

Compound 4, half-maximal cytotoxic concentration in the PC-12 assay: > 100000 nM
Compound 4: no number, only a limit; the forecaster's own chance of this, stated with the estimate: 5%; middle value at least 2.6-fold (0.42 log units) away from the limit.
By their numbers in the PC-12 assay, from the lowest: compounds 2, 3 and 1 (each within the scatter of the next, the first and the last beyond it). At a limit, above all of these: compound 4.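

Among the compounds shown here, in the PC-12 assay, 3-hydroxyphenyl in place of 2-hydroxyphenyl on a double-bonded chain carbon bound to a double-bonded chain carbon gives an at least 2.9-fold higher number from compound 3 to compound 4 (0.46 log units; beyond the scatter), so on this core the place of the hydroxyl on the ring alone moves the result beyond the scatter, which the single modest step on the core of compound 1 could not show. In the PC-12 assay compound 4 gives > 100000 nM, which is a limit and not a number: the limit of > 100000 nM in the PC-12 assay, at which 1 of the 4 values shown sits. In a physicochemical assay for solubility, using the shake flask method, with a stated time of 12 h (a lower number here means a less soluble compound, a higher number a more soluble compound), compound 3 gives 111000 nM and compound 4 gives 60000 nM. In the physicochemical assay the same exchange gives a 1.9-fold lower number from compound 3 to compound 4 (0.27 log units; within the scatter), so the two compounds separate in the cell read-out but not in solubility.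

Going by these compounds, whether the same exchange has a like effect on the core of compound 1 stays open. So does whether an amine or a methoxy group in place of that hydroxyl would give a similar result in the PC-12 assay.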